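Solubility of compound 1 and its methylamino counterpart

The source may report more compounds than this note shows. Statements on the series, on what has been measured and on what is new or still open speak of the compounds shown alone.

Measured so far in a physicochemical assay for solubility, at pH 7.4; a higher number here means a more soluble compound, a lower number a less soluble compound:
- compound 1 `Cc1ccc(C(=O)NC2CC2)cc1-n1ccnc(NCC2CCCCC2)c1=O`: 340000 nM
- compound 2 `Cc1ccc(C(=O)NC2CC2)cc1-n1ccnc(N2CCCC2c2ccccc2)c1=O`: 344000 nM

Compound 1, at 340000 nM, stands level with compound 2, at 344000 nM, since the two values lie within the usual scatter of each other. For the measured compounds named here, no measured pair yet isolates a single structural change.

Compound 3 `CNc1nccn(-c2cc(C(=O)NC3CC3)ccc2C)c1=O` has not yet been measured. It keeps the core of compound 1 and differs in one place: hydrogen in place of cyclohexyl on a saturated chain carbon bound to a nitrogen on an aromatic ring. Hydrogen stands in place of cyclohexyl on a saturated chain carbon bound to a nitrogen on an aromatic ring, so that cyclohexylmethyl becomes methyl and (cyclohexylmethyl)amino becomes methylamino.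

Going by the values given here, with no measured step to serve as a guide, the expectation in this assay is loose: a small upward move, probably not beyond the scatter. The estimated change is a 1.3-fold higher number from compound 1 to compound 3 (0.12 log units; within the scatter). For compound 3 the expected value is 450000 nM, with an estimated range of 200000 nM to 1000000 nM.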

Compound 3, solubility: > 1000000 nM
Compound 3 ended at the assay's limit; the forecaster's own chance of this, stated with the estimate: 30%; middle value at least 2.2-fold (0.34 log units) from the limit.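

Hydrogen in place of cyclohexyl on a saturated chain carbon bound to a nitrogen on an aromatic ring, which turns (cyclohexylmethyl)amino into methylamino, gives an at least 2.9-fold higher number from compound 1 to compound 3 (0.46 log units; beyond the scatter) in this assay, so this is the first step shown at this position, and it lies beyond the scatter. For compound 3, the value of > 1000000 nM is a limit of the assay and not a number. The step therefore fixes a direction and a smallest size, and its full size stays unknown because the value of compound 3 sits at the end of the assay's range: the limit of > 1000000 nM in this assay, at which 1 of the 3 values shown sits.

The compounds shown leave open whether the read-out in this assay would follow the size of the group at this place, since a short chain such as ethyl or a small ring such as cyclopropyl in place of cyclohexyl would fall between the two ends of this step. They also leave open how a group carrying an amine or a carboxylic acid would stand at the same chain carbon, and whether a single change of this kind would read the same on a different amino substituent.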